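From 2-Methoxyphenyl to 3-Methoxyphenyl in a Single Step

The source may report more compounds than this note shows. Statements on the series, on what has been measured and on what is new or still open speak of the compounds shown alone.

For the measured compounds named here, compound 1 `COc1ccccc1/C=C/C(=O)/C=C/c1ccc(OCc2cn(CCOc3cc(=O)oc4ccccc34)nn2)c(OC)c1` is one of three compounds measured in a functional assay on HCT-116 cells (Homo sapiens) for inhibition, read by sulforhodamine B assay, with a stated time of 48 h, tested at 50 uM (a higher number here means more inhibition of growth at the concentration tested, a lower number less inhibition of growth), where compound 1 gives 70%. It stands highest of the three. In this assay compound 2 `COc1cc(/C=C/C(=O)/C=C/c2cccc3ccccc23)ccc1OCc1cn(CCCCOc2cc(=O)oc3ccccc23)nn1` gives 56%, a number lower by more than the usual scatter, and compound 3 `COc1cc(/C=C/C(=O)/C=C/c2ccco2)ccc1OCc1cn(CCCOc2cc(=O)oc3ccccc23)nn1` gives 51%, lower still and likewise beyond the scatter.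

Compound 4 `COc1cccc(/C=C/C(=O)/C=C/c2ccc(OCc3cn(CCOc4cc(=O)oc5ccccc45)nn3)c(OC)c2)c1` keeps every atom of compound 1 but joins them differently: 3-methoxyphenyl in place of 2-methoxyphenyl on a double-bonded chain carbon bound to a double-bonded chain carbon. Going by the values given here, no pair of measured compounds shows such a change, so its effect is unknown. A small step in either direction, not beyond the scatter, is expected; the estimated step of a number 5 percentage points lower from compound 1 to compound 4 (within the scatter) is modest. In this assay compound 4 is expected to give about 65%, with a likely range from 50% to 80%.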

Compound 4, percent growth inhibition at one concentration: 70%
For compound 4 the middle estimate is 5 percentage points below the measured one; measured number inside the range.
By their numbers in this assay, from the lowest: compounds 3 and 2 (each within the scatter of the next); then compounds 1 and 4 (each within the scatter of the next).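

In this assay, for the compounds shown here, putting 3-methoxyphenyl in place of 2-methoxyphenyl on a double-bonded chain carbon bound to a double-bonded chain carbon gives no change at the digits printed from compound 1 to compound 4 (within the scatter) and is the first step that can be read at this position. Moving the methoxy group around this phenyl ring therefore costs no growth inhibition at the concentration tested, at least for this one move.

As far as these compounds go, whether 4-methoxyphenyl or an aminophenyl group in the same place would read alike remains open. No evidence at hand explains why these two compounds match.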